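Swapping the side group on compound 2

A few compounds are considered here, and "the series" means these few. Any claim that something is new, unique, unknown or untested is made for them only; others in the source may bear on it.

Compound 1 `C=C(CO)C(CCCCC)n1cnc2c(Cl)ncnc21`: > 50000 nM (a limit)
Compound 2 `CCCCCCCCC(CCO)n1cnc2c(Cl)ncnc21`: 1370 nM

Within the data shown here, in a functional assay on SW480 cells (Homo sapiens) for antiproliferative activity, read by MTT assay, with a stated time of 48 h (a lower number here means a stronger inhibitor, a higher number a weaker inhibitor), compound 2 gives 1370 nM, the only true number so far. Compound 1 reads > 50000 nM, which is a limit of the assay and not a number.

Compound 3 `C=C(CO)C(CCCCCCCC)n1cnc2c(Cl)ncnc21` differs from compound 2 in one place: 1-(hydroxymethyl)ethenyl in place of 2-hydroxyethyl on a saturated chain carbon bound to an aromatic nitrogen and a saturated chain carbon. Put simply, it has 1-(hydroxymethyl)ethenyl in place of 2-hydroxyethyl on a saturated chain carbon bound to an aromatic nitrogen and a saturated chain carbon.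

Among the measured compounds shown here, no measured pair shows this change alone, so any forecast is uncertain. Compound 1 also carries 1-(hydroxymethyl)ethenyl and reads > 50000 nM, so a modest weakening in this assay is expected, not a gain. The expected size of the change is a 2.2-fold higher number from compound 2 to compound 3 (0.34 log units; beyond the scatter). For compound 3 the estimated value is 3000 nM, with an expected range from 800 nM to 15000 nM.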

Compound 3, half-maximal inhibitory concentration: 16200 nM
Beside the measured number, compound 3's estimate is 5.4-fold (0.73 log units) below it; the measured number lies above the stated range.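

Among these compounds, at this saturated chain carbon bound to an aromatic nitrogen and a saturated chain carbon, 1-(hydroxymethyl)ethenyl in place of 2-hydroxyethyl weakens the compound sharply in this assay, giving a 12-fold higher number from compound 2 to compound 3 (1.07 log units; beyond the scatter), which is the first view of this change on its own. With 1-(hydroxymethyl)ethenyl kept in place, the chain matters too: propyl in place of hydrogen on a saturated chain carbon, six bonds along the chain from an aromatic nitrogen and a double-bonded chain carbon, gives an at least 3.0-fold lower number from compound 1 to compound 3 (0.48 log units; beyond the scatter). The reading of compound 1 is a limit and not a number, so the true size of that step stays unknown: the limit of > 50000 nM in this assay, at which 1 of the 3 values shown sits.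

The new group brings both a double bond and more carbon, and the compounds shown do not separate the two. From the compounds shown here alone, how an amine in place of the hydroxyl group, or a longer chain, would read at these places also stays open.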